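The compounds below may be only part of what the source reports. "The series", "measured", "known", "first", "only" and "open" are said of these compounds alone.

Compound 1 `Cc1nn(-c2ccccc2)c2nc(OCc3ccccc3F)c(-c3nc(N)c(N)c(N)n3)cc12`: 960 nM
Compound 2 `CC(=O)Nc1c(N)nc(-c2cc3c(C)nn(-c4ccccc4)c3nc2OCc2ccccc2F)nc1N`: 930 nM

Both values come from a functional assay on aorta (Rattus norvegicus, strain Sprague-Dawley); on this read-out higher numbers stand for an effect only at larger amounts of compound and lower numbers for an effect already at smaller amounts. For the measured compounds named here, only two compounds have been measured here, so there is little to place compound 2 against. At 930 nM, compound 2 cannot be told apart from compound 1.

Compound 3 `Cc1nn(-c2ccccc2)c2nc(OCc3ccccc3F)c(-c3nc(N)c4c(n3)[nH]c(=O)n4C)cc12` has not yet been measured. Its change is larger than an added acetyl: a group of 12 heavy atoms (6 carbon, 5 nitrogen, 1 oxygen; one five-membered aromatic ring with 2 hetero atoms, one six-membered aromatic ring with 2 hetero atoms) in place of a group of 12 heavy atoms (6 carbon, 5 nitrogen, 1 oxygen; one six-membered aromatic ring with 2 hetero atoms), on an aromatic carbon. The 5-acetamido-4,6-diaminopyrimidin-2-yl group of compound 2 is replaced by a group with two rings, at the same place on the shared core, ortho to a (2-fluorobenzyl)oxy group.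

Going by the values given here, the only measured step that bears on this is a 1.0-fold lower number from compound 1 to compound 2 (0.01 log units; within the scatter), which altered the same group and left the number within the scatter. Among the compounds with values here, that is one small step, and no measured compound contains the new group, so the evidence is thin. No shift beyond the scatter is expected, and the expected step is a 1.0-fold lower number from compound 2 to compound 3 (0.01 log units; within the scatter), with a wide margin in either direction. Compound 3 is estimated at 900 nM, with an expected range from 250 nM to 3000 nM.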

Compound 3, half-maximal effective concentration: 4900 nM
Compound 3: middle estimate off by 5.4-fold (0.74 log units), on the low side; measured number outside the range, above it.
By their numbers in this assay, from the lowest: compounds 2 and 1 (each within the scatter of the next); then compound 3.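

Compound 3 shows that this position, on the aromatic carbon ortho to a (2-fluorobenzyl)oxy group, is not indifferent to what sits there: in this assay there is a 5.3-fold higher number from compound 2 to compound 3 (0.72 log units; beyond the scatter), and there is also a 5.1-fold higher number from compound 1 to compound 3 (0.71 log units; beyond the scatter), whereas adding an acetyl to a ring nitrogen had left the number within the scatter. The leaving 5-acetamido-4,6-diaminopyrimidin-2-yl and the entering two-ring group have the same count of heavy atoms, so in this pair that count alone does not hold the number in place, and a group of the same atom count can still need a larger amount of compound for the effect. Nothing measured here explains why the number rose.

Going by these compounds, the step changes the ring system, the ring carbonyl, the methyl and the count of hydrogen-bond donors all at once, so the share of each in the rise stays open. How this position would respond to a single amine on the pyrimidine, or to a carboxylic acid there, also remains an open question.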